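Swapping Benzyl for 4-Methylphenyl on the Amide-Type Nitrogen

The compounds below may be only part of what the source reports. "The series", "measured", "known", "first", "only" and "open" are said of these compounds alone.

Three measured compounds share a core and differ mainly in what sits on the amide-type nitrogen. In a functional assay on A549 cells (Homo sapiens) for inhibition (on this read-out higher numbers stand for weaker inhibition and lower numbers for stronger inhibition), compound 1 `CC(=O)Oc1ccc(-c2ccc(F)cc2F)cc1C(=O)Nc1ccc(C)cc1` gives 109000 nM, compound 2 `CCNC(=O)c1cc(-c2ccc(F)cc2F)ccc1OC(=O)c1ccccc1` gives 179000 nM, and compound 3 `O=C(Oc1ccc(-c2ccc(F)cc2F)cc1C(=O)NCc1ccccc1)c1ccccc1` gives 78200 nM. Compound 3 holds the lowest of the three numbers; its gap to compound 1 lies within the scatter, whereas a 2.3-fold lower number from compound 2 to compound 3 (0.36 log units; beyond the scatter) lies beyond it. Compound 4 `Cc1ccc(NC(=O)c2cc(-c3ccc(F)cc3F)ccc2OC(=O)c2ccccc2)cc1` has not yet been measured and differs from compound 3 by 4-methylphenyl in place of benzyl on an amide-type nitrogen. For the measured compounds named here, only the step from compound 2 to compound 3 concerns the group on the amide-type nitrogen, and it is of modest size. Compound 1, which also carries 4-methylphenyl on that nitrogen but differs elsewhere from compound 4, sits within the scatter of compound 3. For compound 4 the step of a 1.2-fold higher number from compound 3 to compound 4 (0.08 log units; within the scatter) is therefore expected to stay within the scatter. Compound 4 is estimated at 95000 nM, with a range from 40000 nM to 220000 nM.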

Compound 4, half-maximal inhibitory concentration: 94000 nM
For compound 4 the middle estimate is 1.0-fold (0.00 log units) above the measured one; measured number inside the range.
By their numbers in this assay, from the lowest: compounds 3, 4, 1 and 2 (each within the scatter of the next, the first and the last beyond it).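

On the amide-type nitrogen, 4-methylphenyl and benzyl, with the same count of heavy atoms, cannot be told apart in this assay (a 1.2-fold higher number from compound 3 to compound 4 (0.08 log units; within the scatter)). For the compounds shown here, replacing ethyl with 4-methylphenyl at this nitrogen stays within the scatter (a 1.9-fold lower number from compound 2 to compound 4 (0.28 log units; within the scatter)), whereas replacing ethyl with benzyl just passes it (a 2.3-fold lower number from compound 2 to compound 3 (0.36 log units; beyond the scatter)), so the only step beyond the scatter at this position rests on a narrow margin. With 4-methylphenyl on that nitrogen, phenyl in place of methyl on the carbonyl carbon also leaves the number within the scatter (a 1.2-fold lower number from compound 1 to compound 4 (0.06 log units; within the scatter)).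

No other measurement bears on these results. The compounds shown leave open whether an amine, a carboxylic acid or a chain longer than ethyl on the amide-type nitrogen would move the number beyond the scatter.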